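The compounds below may be only part of what the source reports. "The series", "measured", "known", "first", "only" and "open" are said of these compounds alone.

In a functional assay on HT-29 cells (Homo sapiens) for antiproliferative activity, read by MTT assay, with a stated time of 72 h (on this read-out lower numbers stand for stronger inhibition and higher numbers for weaker inhibition), compound 3 (`Nc1nc(N)c2cc(CSC(=S)N3CCN(c4ccc(Cl)c(Cl)c4)CC3)ccc2n1`) gives 3480 nM, within the scatter of compound 1 (`Cc1ccccc1N1CCN(C(=S)SCc2ccc3nc(N)nc(N)c3c2)CC1`) at 2950 nM and of compound 2 (`Cc1ccc(N2CCN(C(=S)SCc3ccc4nc(N)nc(N)c4c3)CC2)c(C)c1`) at 2970 nM. Compound 4 (`CC(=O)c1ccc(N2CCN(C(=S)SCc3ccc4nc(N)nc(N)c4c3)CC2)cc1`) carries 4-acetylphenyl in place of 3,4-dichlorophenyl on an amine nitrogen in a ring. Among the measured compounds shown here, no measured compound carries an acetyl group, so that feature remains untested. The closest evidence comes from exchanges at the same place, a 1.2-fold higher number from compound 1 to compound 3 (0.07 log units; within the scatter) and a 1.2-fold higher number from compound 2 to compound 3 (0.07 log units; within the scatter), while adding a methyl gave a 1.0-fold higher number from compound 1 to compound 2 (0.00 log units; within the scatter). All three lie within the scatter, so no step beyond the scatter is expected in this assay. The expected step is a 1.2-fold lower number from compound 3 to compound 4 (0.06 log units; within the scatter), with no firm direction. For compound 4 the estimate is 3000 nM, with an expected range of 1300 nM to 7000 nM.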

Compound 4, half-maximal inhibitory concentration: 2280 nM
Estimate against measurement, compound 4: 1.3-fold (0.12 log units) above; low and high end bracket the measured number.
By their numbers in this assay, from the lowest: compounds 4, 1, 2 and 3 (each within the scatter of the next).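

In this assay, 4-acetylphenyl on the amine nitrogen in a ring adds a carbonyl and a hydrogen-bond acceptor, yet every comparison stays within the scatter (a 1.5-fold lower number from compound 3 to compound 4 (0.18 log units; within the scatter); a 1.3-fold lower number from compound 2 to compound 4 (0.11 log units; within the scatter); a 1.3-fold lower number from compound 1 to compound 4 (0.11 log units; within the scatter)). This position therefore accepts an acetyl-bearing aryl group as well as the methyl- and chloro-substituted ones, without a step beyond the scatter. Nothing measured here gives a reason for this. Still open, on these data alone, is whether a carboxylic acid or an amine on this phenyl ring would shift the read-out. As far as these compounds go, replacing the phenyl ring with a simple alkyl chain also remains open.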